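From a fused bicyclic ring to a trifluoromethylpyrazole

This account rests on a few compounds, and the source may have more. Where it says the series, first, only, none or still open, it means among the compounds named here.

Compound 3 `CCOc1ncc(-c2nc(C(F)(F)F)sc2N2CCN(C(=O)Cn3ncc4cccnc43)[C@H](C)C2)cn1` gives 372 nM in an assay on blood for inhibition of C-X-C chemokine receptor type 3 (Homo sapiens), with a stated time of 30 min (on this read-out lower numbers stand for stronger inhibition and higher numbers for weaker inhibition), the lowest of the three numbers measured. Compound 1 `C[C@@H]1CN(c2scnc2-c2nc3ccccc3[nH]2)CCN1C(=O)Cn1cnc2cccnc21` gives 554 nM, which lies within the scatter of compound 3, while compound 2 `Cc1nc(-c2nc3ccccc3[nH]2)c(N2CCN(C(=O)Cn3cnc4cccnc43)[C@H](C)C2)s1` gives 1060 nM, beyond it. Among the compounds with values here, the only single-point step measured, a 1.9-fold higher number from compound 1 to compound 2 (0.28 log units; within the scatter), concerns a different part of the molecule and does not bear on the change considered here. Compound 4 `CCOc1ncc(-c2nc(C(F)(F)F)sc2N2CCN(C(=O)Cn3ccc(C(F)(F)F)n3)[C@H](C)C2)cn1` differs from compound 3 by a group of 9 heavy atoms (4 carbon, 2 nitrogen, 3 fluorine; one five-membered aromatic ring with 2 hetero atoms) in place of a group of 9 heavy atoms (6 carbon, 3 nitrogen; one five-membered aromatic ring with 2 hetero atoms, one six-membered aromatic ring with 1 hetero atom), on a saturated chain carbon bound to a carbonyl carbon. Within the data shown here, no measured step covers this exchange, so its direction cannot be read from the data. The expected step is therefore a 1.5-fold higher number from compound 3 to compound 4 (0.17 log units; within the scatter), small and uncertain. For compound 4 the estimated value is 550 nM, with a likely range from 150 nM to 2000 nM.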

Compound 4, half-maximal inhibitory concentration: 90 nM
For compound 4 the middle estimate is 6.1-fold (0.79 log units) above the measured one; measured number outside the range, below it.
By their numbers in this assay, from the lowest: compound 4; then compounds 3, 1 and 2 (each within the scatter of the next, the first and the last beyond it).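

At this position, on a saturated chain carbon bound to a carbonyl carbon, the group with a five-membered and a six-membered aromatic ring can give way to a single five-membered ring: 3-(trifluoromethyl)-1H-pyrazol-1-yl brings a 4.1-fold lower number from compound 3 to compound 4 (0.62 log units; beyond the scatter) in this assay. The six-membered aromatic ring is therefore not needed for a low number in this pair. No measurement shown explains the step.

Going by these compounds, whether the pyrazole ring or its trifluoromethyl carries the step stays open. No pyrazole with a methyl or a chlorine in place of the trifluoromethyl is among the compounds shown.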